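The source may report more compounds than this note shows. Statements on the series, on what has been measured and on what is new or still open speak of the compounds shown alone.

Three compounds have so far been run in an assay on isolated protein for inhibition of protein arginine N-methyltransferase 6 (Homo sapiens); on this read-out higher numbers stand for weaker inhibition and lower numbers for stronger inhibition. Compound 1 `CNCCNC1CCN(c2cccc(-c3ccnc(C)n3)c2)CC1` gives 8900 nM there. Compound 2 `Cc1cc(OCCNCCN)ccc1C(C)C` is recorded in this assay as "not active" (no number reported), and compound 3 `C[C@@H](N)C(=O)NCc1cccnc1Oc1ccc(F)cc1F` is recorded the same way, as "not active" (no number reported), so compound 3 stands without a number of its own, a status it shares with one further entry. Compound 4 `CC(C)(N)C(=O)NCc1cccnc1Oc1ccc(F)cc1F` has not yet been measured. It differs from compound 3 only in 1-amino-1-methylethyl in place of 1-aminoethyl on a carbonyl carbon. Going by the values given here, with compound 3 inactive and no step between measured compounds to lean on, compound 4 is expected to stay close to compound 3, with no movement beyond the usual scatter foreseen in either direction. Compound 4 is therefore estimated at 30000 nM in this assay, within a range from 5000 nM to 200000 nM, and it may well return no number at all.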

Compound 4, half-maximal inhibitory concentration: "not active" (no number reported)
No number was reported for compound 4; no gap can be computed for the estimate.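

In this assay compound 3 and compound 4 both return no number, so no step can be read between them. As far as these compounds go, whether 1-amino-1-methylethyl in place of 1-aminoethyl alters inhibition stays open, and no measured evidence bears on this.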